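The source may hold more compounds than are shown below. What is called first, only, known or untested is meant among the compounds shown, and "the series" means these compounds.

Working notes on the series

The shared core is carried by compound 1 `CCCCCCCCCCn1cc(-c2nc3ccccc3cc2C)nn1`; in a functional assay on COLO 205 cells (Homo sapiens) for cytotoxicity, read by MTT assay, with a stated time of 24 h (a higher number here means a weaker inhibitor, a lower number a stronger inhibitor), compound 1 gives 44.5 ug/mL. Compound 2 `CCCCCCCCCCn1cc(-c2nc3ccccc3cc2CCCC)nn1` carries a longer chain at the same place. In this assay compound 2 reaches only > 100 ug/mL, a limit of the measurement and not a number. Compound 3 `CCCCCCCCCCn1cc(-c2nc3ccccc3cc2CC)nn1` likewise reaches only > 100 ug/mL in this assay, again a limit rather than a number. The step of an at least 2.2-fold higher number from compound 1 to compound 2 (0.35 log units; beyond the scatter) and the step of an at least 2.2-fold higher number from compound 1 to compound 3 (0.35 log units; beyond the scatter) move in the same direction; the step that the two limits leave unreadable from compound 2 to compound 3 cannot be read because both of its ends sit at the limit of > 100 ug/mL in this assay, at which 2 of the 3 values shown sit. Compound 3 therefore stands at the weak end of what the numbers show, without a value of its own.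

Compound 4 `CCCCCCCCCCn1cc(-c2nc3ccccc3cc2CCC)nn1` differs from compound 3 by methyl in place of hydrogen on a saturated chain carbon, two bonds along the chain from an aromatic carbon. Both chain-bearing analogues, compound 2 and compound 3, sit at the same limit, and the two steps from compound 1 point the same way. The step that the limit leaves unreadable from compound 3 to compound 4 is expected to stay unreadable. Compound 4 is expected to remain at the limit in this assay, estimated at 130 ug/mL, with a range from 80 ug/mL to 300 ug/mL.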

Compound 4, half-maximal inhibitory concentration: > 100 ug/mL
Compound 4: no number, only a limit; the forecaster's own chance of this, stated with the estimate: 85%; the middle value is on the limit's open side.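

With compound 4, a third chain longer than the methyl of compound 1 shows the same direction at this position: the change gives an at least 2.2-fold higher number from compound 1 to compound 4 (0.35 log units; beyond the scatter). The steps from compound 3 to compound 4 and from compound 2 to compound 4 cannot be read, and no order among these three compounds can be drawn. In this assay only compound 1 keeps a number, 44.5 ug/mL. The other three compounds share a limit and not a number: the limit of > 100 ug/mL in this assay, at which 3 of the 4 values shown sit.

As far as these compounds go, what an amine or a carboxylic acid would do at this position stays open. Also open, from the compounds shown here alone, is how far compound 2, compound 3 and compound 4 differ beyond the limit.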